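The source may report more compounds than this note shows. Statements on the series, on what has been measured and on what is new or still open speak of the compounds shown alone.

Measured compounds and their values in an ADME assay on microsomes from liver (Homo sapiens) for metabolic stability, read by LC-MS, tested at 0.5 uM; a higher number here means that the compound lasts longer, a lower number that the compound disappears faster:
Compound 1, `Cc1cc(CCOc2ccc(-c3c(C)nc(C)c([C@H](OC(C)(C)C)C(=O)O)c3N3CCC(C)(C)CC3)cc2)ccc1F`, gives > 2 h in this assay, a limit of the assay rather than a number.
Compound 2, `Cc1nc(C)c([C@H](OC(C)(C)C)C(=O)O)c(N2CCC(C)(C)CC2)c1-c1ccc(OCCCc2ccc(F)cc2)cc1`, gives > 2 h in this assay, again a limit of the assay.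
Compound 3, `Cc1nc(C)c([C@H](OC(C)(C)C)C(=O)O)c(N2CCC(C)(C)CC2)c1-c1ccc(OCCc2ccccn2)cc1`, gives 0.5 h in this assay.

Compound 1 therefore stands at the limit of > 2 h in this assay, at which 2 of the 3 values shown sit, so its own position is known only as a limit. The step from compound 1 to compound 2 is a step that the two limits leave unreadable from compound 1 to compound 2. The step to compound 3 is clearer: an at least 4.0-fold lower number from compound 1 to compound 3 (0.60 log units; beyond the scatter), and likewise an at least 4.0-fold lower number from compound 2 to compound 3 (0.60 log units; beyond the scatter).

Compound 4, `Cc1nc(C)c([C@H](OC(C)(C)C)C(=O)O)c(N2CCC(C)(C)CC2)c1-c1ccc(OCCc2cccnc2)cc1`, has not yet been measured in this assay. It differs from compound 1 by pyridin-3-yl in place of 4-fluoro-3-methylphenyl on a saturated chain carbon, two bonds along the chain from an oxygen on an aromatic ring. The measured steps that bear on this change are those to compound 3, in which a pyridin-2-yl ring also enters at the same place and the half-life falls by at least a modest amount. Compound 4 is therefore expected to show a step of an at least 3.3-fold lower number from compound 1 to compound 4 (0.52 log units; beyond the scatter), a drop in the same direction and of a similar size. The estimate for compound 4 in this assay is 0.6 h, expected to lie between 0.3 h and 1.5 h.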

Compound 4, half-life: 0.367 h
Compound 4: the middle estimate sits 1.6-fold (0.21 log units) above what was measured, within the range that was stated.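

In this assay, the fall seen with pyridin-2-yl is not confined to that one ring. Pyridin-3-yl at the same place also gives an at least 5.4-fold lower number from compound 1 to compound 4 (0.73 log units; beyond the scatter) and an at least 5.4-fold lower number from compound 2 to compound 4 (0.73 log units; beyond the scatter). The choice between the two pyridine rings makes no readable difference, with a 1.4-fold lower number from compound 3 to compound 4 (0.13 log units; within the scatter). From the compounds shown here alone, the full size of these falls stays unknown, since compound 1 and compound 2 each stand at a limit of the assay and not at a number: the limit of > 2 h in this assay, at which 2 of the 4 values shown sit.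

The compounds shown leave open whether an unsubstituted phenyl ring on this chain would stay with compound 1 and compound 2 or fall with compound 3 and compound 4. They also leave open whether a fluorine atom or a methyl group on the pyridin-3-yl ring would change the half-life.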